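Tert-butyl for trifluoromethyl on two cores

The source may report more compounds than this note shows. Statements on the series, on what has been measured and on what is new or still open speak of the compounds shown alone.

Compound 1 `CC1CCN(c2cc(C(F)(F)F)ccc2CNC(=O)C(C)c2ccc3c(c2)CCC3)CC1` gives 96.4 nM in an assay on CHO-K1 cells for antagonist activity at transient receptor potential cation channel subfamily V member 1 (Homo sapiens), read by FLIPR; a higher number here means a weaker inhibitor, a lower number a stronger inhibitor. Compound 2 `CC1CCN(c2cc(C(C)(C)C)ccc2CNC(=O)C(C)c2ccc3c(c2)CCC3)CC1` carries tert-butyl in place of trifluoromethyl on an aromatic carbon and gives 61.7 nM in this assay; the step is a 1.6-fold lower number from compound 1 to compound 2 (0.19 log units; within the scatter). Compound 3 `CC(C(=O)NCc1cc(C(F)(F)F)nn1-c1ccc(C(F)(F)F)cc1)c1ccc2c(c1)CCC2` rests on a different core; the difference between the two cores is not broken down here. In this assay compound 3 gives 51.3 nM, and its gaps to compound 2 and to compound 1 both lie within the scatter. Compound 4 `CC(C(=O)NCc1cc(C(C)(C)C)nn1-c1ccc(C(F)(F)F)cc1)c1ccc2c(c1)CCC2` differs from compound 3 by tert-butyl in place of trifluoromethyl on an aromatic carbon. This is the same kind of change as from compound 1 to compound 2, but the place differs: on an aromatic carbon of a five-membered aromatic ring with 2 nitrogen, next to the ring nitrogen, two ring bonds from the ring atom that bears a 4-(trifluoromethyl)phenyl group, rather than on a six-membered aromatic ring of carbon only, meta to a 4-methylpiperidin-1-yl group and para to a large group. Among the compounds with values here, only one such step is measured, on the other core. The step from compound 3 to compound 4 in this assay is expected to be a 1.3-fold lower number from compound 3 to compound 4 (0.11 log units; within the scatter), which rests on the step of a 1.6-fold lower number from compound 1 to compound 2 (0.19 log units; within the scatter). Compound 4 is estimated to give about 40 nM in this assay, in a range from 15 nM to 120 nM.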

Compound 4, inhibition constant: 62.4 nM
Beside the measured number, compound 4's estimate is 1.6-fold (0.19 log units) below it; measured number inside the range.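

In this assay, tert-butyl in place of trifluoromethyl on the aromatic carbon of the five-membered ring gives a 1.2-fold higher number from compound 3 to compound 4 (0.09 log units; within the scatter), so on this core, as on the core of compound 1, the change produces no step beyond the scatter. With both steps this small, neither gives a direction for the change, and the pair shows only that tert-butyl and trifluoromethyl are not told apart by this read-out at these two places; it does not show how the change would behave on a third core or at another place on these two. The two steps themselves cannot be told apart: the same change on two cores in this assay, a 1.6-fold lower number (0.19 log units; within the scatter) from compound 1 to compound 2 and a 1.2-fold higher number (0.09 log units; within the scatter) from compound 3 to compound 4, 1.9-fold (0.28 log units) apart, within the scatter of two such steps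

The compounds shown leave open what other groups on the same aromatic carbon would give, for instance a nitrile, an amine or a carboxylic acid. They also leave open whether a step beyond the scatter on one core would carry over to the other.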